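Thiazol-2-yl in place of dimethoxyphenyl on the ring nitrogen

The compounds below may be only part of what the source reports. "The series", "measured", "known", "first", "only" and "open" are said of these compounds alone.

Compound 1 `COc1ccc(OC)c(N2C(=O)CSC2c2cccc(C(=O)NCCCCc3ccccc3)c2)c1` gives > 1000 nM in a functional assay on HOS-TE85 cells (Homo sapiens) for inhibition, read by CCK-8 assay, with a stated time of 72 h (a lower number here means a stronger inhibitor, a higher number a weaker inhibitor), which is a limit of the assay and not a number. Compound 2 `COc1ccccc1N1C(=O)CSC1c1cccc(C(=O)NCCCCn2cncn2)c1` likewise gives only a limit, > 1000 nM, in this assay. Compound 3 `COc1ccccc1N1C(=O)C(C)SC1c1cccc(C(=O)NCCCCc2ccccc2)c1` gives 45.1 nM in this assay. Compound 1 thus stands at the limit (the limit of > 1000 nM in this assay, at which 2 of the 3 values shown sit), with no number of its own. Compound 4 `O=C(NCCCCc1ccccc1)c1cccc(C2SCC(=O)N2c2nccs2)c1` differs from compound 1 by 1,3-thiazol-2-yl in place of 2,5-dimethoxyphenyl on an amide-type nitrogen in a ring. Within the data shown here, no step between measured compounds sizes this change, so only a direction can be stated: a step toward stronger inhibition in this assay is expected, of uncertain size. Compound 4 is estimated at 700 nM, within 150 nM to 3000 nM. The expected step is an at least 1.4-fold lower number from compound 1 to compound 4 (0.15 log units; that floor lies within the scatter).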

Compound 4, half-maximal inhibitory concentration: > 1000 nM
Compound 4: only a limit was reported; the forecaster's own chance of this, stated with the estimate: 40%; middle value at least 1.4-fold (0.15 log units) away from the limit.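

Among these compounds, compound 1 and compound 4 both sit at a limit and not at a number, so no step between them can be read: the limit of > 1000 nM in this assay, at which 3 of the 4 values shown sit. On these data alone, whether 1,3-thiazol-2-yl in place of 2,5-dimethoxyphenyl changes inhibition at all remains open.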